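The source may hold more compounds than are shown below. What is called first, only, known or untested is meant among the compounds shown, and "the series" means these compounds.

Compound 1 `O=C(COc1ccc(C(=O)/C=C/c2ccc(Cl)cc2Cl)cc1)N[C@H]1CCOC1=O`: 26500 nM
Compound 2 `O=C1OCC[C@@H]1NC(=S)SCCOc1cccc2ccccc12`: > 64000 nM
Compound 3 `O=C1OCC[C@@H]1NC(=S)SCCOc1ccccc1Cc1ccccc1`: 32300 nM

In a functional assay on MGC-803 cells (Homo sapiens) for antiproliferative activity, read by MTT assay, with a stated time of 72 h (on this read-out higher numbers stand for weaker inhibition and lower numbers for stronger inhibition), compound 1 gives 26500 nM, the lowest of the two numbers recorded. Compound 3 gives 32300 nM in this assay, a gap to compound 1 that sits within the scatter. For compound 2 the result in this assay is a limit of the assay, > 64000 nM, and not a number (the limit of > 64000 nM in this assay, at which 1 of the 3 values shown sits).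

Compound 4 `O=C(COc1ccc(C(=O)/C=C/c2ccc(F)cc2)cc1)N[C@H]1CCOC1=O` differs from compound 1 by 4-fluorophenyl in place of 2,4-dichlorophenyl on a double-bonded chain carbon bound to a double-bonded chain carbon. Going by the values given here, no measured pair shows this change, so its effect is unknown. The step from compound 1 to compound 4 in this assay is expected to be small, in the direction of weaker inhibition, at the edge of the scatter a 1.4-fold higher number from compound 1 to compound 4 (0.16 log units; within the scatter). Compound 4 is thus estimated at 38000 nM, between 15000 nM and 90000 nM.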

Compound 4, half-maximal inhibitory concentration: > 64000 nM
Compound 4: only a limit was reported; the forecaster's own chance of this, stated with the estimate: 25%; at least 1.6-fold (0.22 log units) between middle value and limit.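

In this assay, going by these compounds alone, 4-fluorophenyl in place of 2,4-dichlorophenyl on a double-bonded chain carbon bound to a double-bonded chain carbon gives the first readable step in this set, an at least 2.4-fold higher number from compound 1 to compound 4 (0.38 log units; beyond the scatter), which shows that inhibition responds to the group held at this position. Compound 4 reads as a limit of the assay and not a number: the limit of > 64000 nM in this assay, at which 2 of the 4 values shown sit.

The compounds shown leave open how far compound 4 lies past its limit, and whether losing the chlorines or gaining the fluorine drives the step. On these data alone, whether a 4-chlorophenyl group at this position would keep the inhibition seen with compound 1 also remains open.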